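The source may hold more compounds than are shown below. What is called first, only, known or untested is meant among the compounds shown, and "the series" means these compounds.

Compound 1 `Oc1ccc(-c2cc(-c3ccsc3)cc(-c3ccccc3O)n2)cc1` and compound 2 `Oc1ccc(-c2cc(-c3ccsc3)cc(-c3ccc(O)cc3)n2)cc1` share one core carrying three aromatic groups. In a functional assay on HeLa cells (Homo sapiens) for cytotoxicity, read by CCK-8 assay (on this read-out lower numbers stand for stronger inhibition and higher numbers for weaker inhibition), compound 1 gives only a limit, > 50000 nM, namely (the limit of > 50000 nM in this assay, at which 1 of the 2 values shown sits). In this assay, for the measured compounds named here, compound 2 gives 4370 nM, the only number here, so it stands alone. The step of an at least 11-fold lower number from compound 1 to compound 2 (1.05 log units; beyond the scatter) is the single measured one, and it touches a different position than the change to compound 3 `Oc1ccc(-c2cc(-c3ccco3)cc(-c3ccc(O)cc3)n2)cc1`, which is furan-2-yl in place of thiophen-3-yl on an aromatic carbon. Going by the values given here, no measured step bears on this change, so no step beyond the scatter is expected. Compound 3 is estimated at 4500 nM, between 1500 nM and 13000 nM. This expected step is a 1.0-fold higher number from compound 2 to compound 3 (0.01 log units; within the scatter).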

Compound 3, half-maximal inhibitory concentration: > 50000 nM
Compound 3: only a limit was reported; the forecaster's own chance of this, stated with the estimate: 10%; at least 11-fold (1.04 log units) between middle value and limit.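

In this assay, replacing thiophen-3-yl with furan-2-yl, groups of equal heavy-atom count, gives an at least 11-fold higher number from compound 2 to compound 3 (1.05 log units; beyond the scatter). For the compounds shown here, the only earlier step changed a hydroxyphenyl group, so this is the first sign that the group opposite the ring nitrogen also matters. Compound 3 gives only a limit, so the true size of this step stays unknown: the limit of > 50000 nM in this assay, at which 2 of the 3 values shown sit.

The change swaps both the ring's hetero atom and its point of attachment, and these two cannot be separated here. Furan-3-yl or thiophen-2-yl at this position would tell them apart.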